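Furan-2-yl for thiophen-3-yl on the carbonyl: working notes

This account rests on a few compounds, and the source may have more. Where it says the series, first, only, none or still open, it means among the compounds named here.

In a physicochemical assay for solubility, read by HPLC, with a stated time of 24 h (a higher number here means a more soluble compound, a lower number a less soluble compound), compound 1 (`CC(C)(C)c1[nH]cnc1/C=c1\[nH]c(=O)/c(=C/c2cccc(C(=O)N3CCCCC3)c2)[nH]c1=O`) gives < 0.1 ug/mL as a limit of the assay, not a number. Compound 2 (`CC(C)(C)c1[nH]cnc1/C=c1\[nH]c(=O)/c(=C/c2cccc(C(=O)c3ccsc3)c2)[nH]c1=O`) gives < 0.1 ug/mL as a limit too, so it stands without a number. For the measured compounds named here, the one measured step (a step that the two limits leave unreadable from compound 1 to compound 2) offers no size to carry forward, and the evidence (the limit of < 0.1 ug/mL in this assay, at which 2 of the 2 values shown sit) adds no number. Compound 3 (`CC(C)(C)c1[nH]cnc1/C=c1\[nH]c(=O)/c(=C/c2cccc(C(=O)c3ccco3)c2)[nH]c1=O`) carries furan-2-yl in place of thiophen-3-yl on a carbonyl carbon. With no measured size to scale this change, no step beyond the usual scatter is expected in this assay and no direction is favoured, and the estimated step reads accordingly (a number no lower from compound 2 to compound 3 (the limit leaves the size open)). Compound 3 is expected at 0.1 ug/mL with an estimated range from 0.03 ug/mL to 0.4 ug/mL and may well return only a limit.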

Compound 3, solubility: < 0.1 ug/mL
Compound 3: only a limit was reported (the forecaster's own chance of this, stated with the estimate: 75%); the middle value lies on the limit itself.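

In this assay compound 3 gives < 0.1 ug/mL, a limit of the assay and not a number. The steps among compound 1, compound 2 and compound 3 cannot be read. The compounds shown leave open whether piperidin-1-yl, thiophen-3-yl and furan-2-yl on the carbonyl carbon differ at all in solubility.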